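Swapping a Fluoro for a Trifluoromethyl on the Benzyl Ring

The compounds below may be only part of what the source reports. "The series", "measured", "known", "first", "only" and "open" are said of these compounds alone.

Of the compounds shown here, two sharing one core have been measured in an assay on microsomes from liver for inhibition of 3-hydroxy-3-methylglutaryl-coenzyme A reductase (Rattus norvegicus); a higher number here means a weaker inhibitor, a lower number a stronger inhibitor. Compound 1 `CC(C)c1c(C(=O)N(C)Cc2ccccc2)nn(-c2ccc(F)cc2)c1OC[C@@H](O)C[C@@H](O)CC(=O)O` gives 5.2 nM. Compound 2 `CC(C)c1c(C(=O)N(C)Cc2cccc(F)c2)nn(-c2ccc(F)cc2)c1OC[C@@H](O)C[C@@H](O)CC(=O)O` gives 14 nM. Going by the values given here, compound 2 thus has the highest of the two numbers, and the only measured step, a 2.7-fold higher number from compound 1 to compound 2 (0.43 log units; beyond the scatter), is a modest weakening brought about by a fluoro in place of hydrogen on an aromatic carbon.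

Compound 3 `CC(C)c1c(C(=O)N(C)Cc2cccc(C(F)(F)F)c2)nn(-c2ccc(F)cc2)c1OC[C@@H](O)C[C@@H](O)CC(=O)O` takes the next step on that same ring: trifluoromethyl in place of fluoro on an aromatic carbon. Among the compounds with values here, no measured pair shows what a trifluoromethyl does at this place, so the expectation rests only on the step from compound 1 to compound 2. That step shows that adding a group on this aromatic carbon cost a little inhibition, and a larger group is expected to cost about as much again or somewhat more, although a result within the scatter cannot be ruled out. The step of a 2.0-fold higher number from compound 2 to compound 3 (0.30 log units; within the scatter) is therefore estimated as a modest further weakening. Compound 3 is expected to give about 28 nM, within a range from 9 nM to 90 nM in this assay.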

Compound 3, half-maximal inhibitory concentration: 31 nM
Estimate against measurement, compound 3: 1.1-fold (0.04 log units) below; low and high end bracket the measured number.
By their numbers in this assay, from the lowest: compound 1; then compound 2; then compound 3.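

With trifluoromethyl, this aromatic carbon of the benzyl ring now carries three different substituents, and in this assay the order runs from hydrogen through fluoro to trifluoromethyl, with each replacement giving a weaker inhibitor. The earlier pair showed only that one fluoro costs some inhibition; the new result shows that the loss continues when fluoro, with 1 heavy atom, gives way to trifluoromethyl, with 4 heavy atoms, as a 2.2-fold higher number from compound 2 to compound 3 (0.35 log units; beyond the scatter) makes clear, and that the whole change from hydrogen adds up to a 6.0-fold higher number from compound 1 to compound 3 (0.78 log units; beyond the scatter), still a modest loss in this series. No supporting measurement is available to explain this order.

Three compounds cannot show whether the trend follows the number of heavy atoms or something else about these fluorine-bearing groups, and a methyl, a methoxy, an amine or a carboxylic acid at this same carbon would help to separate those possibilities. As far as these compounds go, it also remains open whether fluoro or trifluoromethyl on the other carbons of this ring would cost as much, and whether any group here could match or improve on hydrogen.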